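This account rests on a few compounds, and the source may have more. Where it says the series, first, only, none or still open, it means among the compounds named here.

Working notes on the series.

Compound 2 `COc1cc(C(=O)Nc2nc(-c3cc(OC)c(OC)c(OC)c3)cs2)cc(OC)c1OC` carries the shared core with a fully methoxylated amide aryl ring. In a functional assay on MDA-MB-231 cells (Homo sapiens), read by microscopy and transwell migration, with a stated time of 24 h (on this read-out higher numbers stand for weaker inhibition and lower numbers for stronger inhibition), compound 2 gives 1030 nM. Compound 1 `COc1ccc(C(=O)Nc2nc(-c3cc(OC)c(OC)c(OC)c3)cs2)cc1OC` differs from it by hydrogen in place of methoxy on an aromatic carbon. In this assay compound 1 gives > 25000 nM, which is a limit of the assay and not a number. The step of an at least 24-fold higher number from compound 2 to compound 1 (1.38 log units; beyond the scatter) is therefore open-ended because the limit of > 25000 nM in this assay, at which 1 of the 3 values shown sits, caps what the read-out can report. Compound 3 `COc1cc(-c2csc(N(C)C(=O)c3cccc(OC)c3OC)n2)cc(OC)c1OC` has a different amide part; the difference between its core and that of compound 2 is not broken down here. In this assay compound 3 gives 108 nM, the lowest number of the two measured.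

Compound 4 `COc1ccccc1C(=O)N(C)c1nc(-c2cc(OC)c(OC)c(OC)c2)cs1` is not yet measured and differs from compound 3 by hydrogen in place of methoxy on an aromatic carbon. Among the compounds with values here, this is the same kind of change as the one from compound 2 to compound 1, but the place is not identical: in the pair measured so far the leaving methoxy also sits meta to a methoxy group, whereas in compound 3 it does not, and the wider description reads 2,3-dimethoxyphenyl to 2-methoxyphenyl. Within the data shown here, with only one measured instance of the change, and that one at a limit, the expected step of a 14-fold higher number from compound 3 to compound 4 (1.14 log units; beyond the scatter) is set weaker than the step of an at least 24-fold higher number from compound 2 to compound 1 (1.38 log units; beyond the scatter) but still toward a higher number. Compound 4 is expected to give about 1500 nM in this assay, within 300 nM to 10000 nM.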

Compound 4, half-maximal inhibitory concentration: > 25000 nM
Compound 4 gave a limit, no number; the forecaster's own chance of this, stated with the estimate: 15%; middle value at least 16-fold (1.22 log units) from the limit.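

In this assay compound 4 gives > 25000 nM, which is a limit of the assay and not a number. The new step, an at least 230-fold higher number from compound 3 to compound 4 (2.36 log units; beyond the scatter), runs in the same direction as the earlier one, so across these two pairs hydrogen in place of methoxy on an aromatic carbon carries over from one core to the other as a move toward weaker inhibition: the same change on two cores in this assay, an at least 24-fold higher number (1.38 log units; beyond the scatter) from compound 2 to compound 1 and an at least 230-fold higher number (2.36 log units; beyond the scatter) from compound 3 to compound 4; the limit leaves it open whether they differ. This does not show that the size of the step carries over, or that one core tolerates the change better than the other, because both steps end at a limit: the limit of > 25000 nM in this assay, at which 2 of the 4 values shown sit.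

The compounds shown leave open whether another group at this place, such as a hydroxyl, an amine or an ethoxy chain, would keep a measurable number in this assay. They also leave open what the methyl on the amide nitrogen contributes on its own, as no pair shown separates it from the arrangement of methoxy groups on the amide aryl ring.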